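Sec-butoxy for 4-chlorophenyl on a carbonyl carbon

The source may hold more compounds than are shown below. What is called first, only, known or untested is meant among the compounds shown, and "the series" means these compounds.

Measured so far in a functional assay on ID8 cells (Mus musculus) for antiproliferative activity; on this read-out lower numbers stand for stronger inhibition and higher numbers for weaker inhibition:
compound 1 `O=C(Nc1ccc(O)c2c(=O)cc(-c3ccccc3Cl)oc12)c1ccc(Cl)cc1` reads 5500 nM
compound 2 `O=C(Nc1c(O)cc(O)c2c(=O)cc(-c3ccccc3Cl)oc12)c1ccc(Cl)cc1` reads "not determined" (no result reported)
compound 3 `CSCC[C@H](NC(=O)OC(C)(C)C)C(=O)Nc1ccc(O)c2c(=O)cc(-c3ccccc3Cl)oc12` reads 6200 nM

Compound 1 and compound 3 lie within the usual scatter of each other, and compound 2 has no number to compare. Compound 4 `CCC(C)OC(=O)Nc1ccc(O)c2c(=O)cc(-c3ccccc3Cl)oc12` has not been measured. Its change from compound 1 reads sec-butoxy in place of 4-chlorophenyl on a carbonyl carbon and amounts to sec-butoxy in place of 4-chlorophenyl on a carbonyl carbon. Among the measured compounds shown here, no measured pair isolates this swap, so the expectation is loose. It rests on compound 1 at 5500 nM and compound 3 at 6200 nM in one range. A modest move toward a weaker number is expected (a 1.3-fold higher number from compound 1 to compound 4 (0.10 log units; within the scatter)) and it may not exceed the scatter. For compound 4 the estimated value is 7000 nM with an expected range from 2500 nM to 20000 nM until a measurement exists.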

Compound 4, half-maximal inhibitory concentration: 18000 nM
Compound 4: the middle estimate sits 2.6-fold (0.41 log units) below what was measured; measured number inside the range.
By their numbers in this assay, from the lowest: compounds 1 and 3 (each within the scatter of the next); then compound 4.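

In this assay, putting sec-butoxy in place of 4-chlorophenyl on a carbonyl carbon gives a 3.3-fold higher number from compound 1 to compound 4 (0.51 log units; beyond the scatter) and so weakens inhibition. Among the compounds shown here, until now, no step isolated a single change, so this is the first sign that the group on this carbonyl carbon matters to the read-out. The change removes the aromatic ring and adds an oxygen, and this single step cannot separate those two parts.

From the compounds shown here alone, whether an unsubstituted phenyl, a simple amine or a longer alkyl chain would be tolerated here stays open. Nothing available explains the loss.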